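The source may report more compounds than this note shows. Statements on the series, on what has been measured and on what is new or still open speak of the compounds shown alone.

In a toxicity assay on Vero cells (Chlorocebus sabaeus) for cytotoxicity, read by MTT assay (a lower number here means a stronger inhibitor, a higher number a weaker inhibitor), compound 1 `COC(=O)NC(=O)c1ccsc1NC(=O)c1ccc(S(=O)(=O)N2CCCC2)cc1` gives 39.5 ug/mL as its reading and compound 2 `COC(=O)NC(=O)c1ccsc1NC(=O)c1ccc(S(=O)(=O)NC2CCOCC2)cc1` gives 35.7 ug/mL as its reading. Among the measured compounds shown here, compound 1 therefore stands level with the only other measured compound, the two values lying within the scatter of each other.

Compound 3 `CCOC(=O)NC(=O)c1ccsc1NC(=O)c1ccc(S(=O)(=O)N2CCCC2)cc1` differs from compound 1 by methyl in place of hydrogen on a saturated chain carbon bound to an oxygen next to a carbonyl group and the same difference reads methoxycarbonyl to ethoxycarbonyl. For the measured compounds named here, no measured step touches this place. Going by the values given here, the one step available is a 1.1-fold lower number from compound 1 to compound 2 (0.04 log units; within the scatter) and it puts (oxan-4-yl)amino in place of pyrrolidin-1-yl on a sulfonyl sulfur, so it bears on the new change only indirectly. It shows a series whose two readings sit together, and it says nothing about the methoxycarbonyl group.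

With so little to go on, no step beyond the scatter is expected in this assay and neither direction is favoured. The estimate amounts to a 1.1-fold lower number from compound 1 to compound 3 (0.04 log units; within the scatter) as an expected step that stays within the scatter. For compound 3 the estimated value is 36 ug/mL with an expected range from 18 ug/mL to 70 ug/mL on this read-out.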

Compound 3, half-maximal inhibitory concentration: 58.2 ug/mL
The estimate for compound 3 lay 1.6-fold (0.21 log units) below the measured number, and the stated range covers the measured number.
By their numbers in this assay, from the lowest: compounds 2, 1 and 3 (each within the scatter of the next).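

In this assay, among the compounds shown here, this is the first reading at the alkyl end of the carbamate-type ester, and methoxycarbonyl to ethoxycarbonyl gives a 1.5-fold higher number from compound 1 to compound 3 (0.17 log units; within the scatter). Adding methyl on a saturated chain carbon bound to an oxygen next to a carbonyl group therefore produces no step beyond the scatter, and the same holds for the only earlier change, on a sulfonyl sulfur, at a 1.1-fold lower number from compound 1 to compound 2 (0.04 log units; within the scatter). So the series now has two places that have each been changed once without a step beyond the scatter in this assay, although a single methyl is a small probe of this position and no measurement at hand offers an explanation for the reading.

Still open, on these data alone, is whether a longer chain such as butyl, a branched group such as tert-butyl, or a benzyl group at this oxygen would give a step beyond the scatter, and whether replacing the ester with a carboxylic acid would do so. Also open, as far as these compounds go, is how ethoxycarbonyl reads when paired with (oxan-4-yl)amino on the sulfonyl sulfur.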